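This account rests on a few compounds, and the source may have more. Where it says the series, first, only, none or still open, it means among the compounds named here.

In an ADME assay on BaF3 cells (Mus musculus) for antiproliferative activity, read by CCK-8 assay, with a stated time of 72 h; on this read-out higher numbers stand for weaker inhibition of growth and lower numbers for stronger inhibition of growth:
- compound 1 `COc1cccc(NC(=O)CCSc2ccc3c(/C=C/c4ccccn4)n[nH]c3c2)c1`: 3840 nM
- compound 2 `O=C(CCSc1ccc2c(/C=C/c3ccccn3)n[nH]c2c1)Nc1ccc(F)c(C(F)(F)F)c1`: 610 nM

Of these two, compound 2 gives the lower number, 610 nM. Compound 3 `CCN1CCN(Cc2ccc(NC(=O)CCSc3ccc4c(/C=C/c5ccccn5)n[nH]c4c3)cc2C(F)(F)F)CC1` differs from compound 2 by (4-ethylpiperazin-1-yl)methyl in place of fluoro on an aromatic carbon at one place. It has (4-ethylpiperazin-1-yl)methyl in place of fluoro on an aromatic carbon. For the measured compounds named here, only one measured step bears on this, the modest 6.3-fold lower number from compound 1 to compound 2 (0.80 log units; beyond the scatter), which also alters the group on the amide-type nitrogen. Going by the values given here, no measured compound carries the entering group, so support is thin. A similarly modest estimated step of a 2.4-fold lower number from compound 2 to compound 3 (0.39 log units; beyond the scatter) is expected in this assay. Compound 3 is expected at 250 nM, with an estimated range of 60 nM to 1000 nM.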

Compound 3, concentration for 50% growth inhibition: 840 nM
Compound 3: the middle estimate sits 3.4-fold (0.53 log units) below what was measured; low and high end bracket the measured number.
By their numbers in this assay, from the lowest: compounds 2 and 3 (each within the scatter of the next); then compound 1.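

In this assay, the aromatic carbon ortho to the trifluoromethyl group accepts (4-ethylpiperazin-1-yl)methyl in place of fluoro, with a 1.4-fold higher number from compound 2 to compound 3 (0.14 log units; within the scatter). The earlier step changed the whole group on the amide-type nitrogen, whereas this one isolates a single position and shows that a group of 9 heavy atoms with a non-aromatic ring can sit there with no change beyond the scatter. Nothing available accounts for this result.

On these data alone, whether a morpholine, a dimethylamine or a carboxylic acid at this position would give a similar number remains open. So does the role of the ethyl on the piperazine.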